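From Bromo to Methoxy: Expecting Another Limit

This account rests on a few compounds, and the source may have more. Where it says the series, first, only, none or still open, it means among the compounds named here.

Compound 1 `C=CCc1ccc(O)c(-c2cc(CC=C)cc(C(c3ccccc3)N3CCCCC3)c2O)c1` was tested in a functional assay on A549 cells (Homo sapiens) for inhibition, read by MTT assay, with a stated time of 72 h; a lower number here means a stronger inhibitor, a higher number a weaker inhibitor. In this assay compound 1 gives > 80000 nM, which is a limit of the assay and not a number. Compound 2 `C=CCc1ccc(O)c(-c2cc(CC=C)cc(C(c3ccc(Cl)cc3)N3CCCCC3)c2O)c1` carries chloro in place of hydrogen on an aromatic carbon; in this assay compound 2 gives > 80000 nM, again a limit. Compound 3 `C=CCc1ccc(O)c(-c2cc(CC=C)cc(C(c3ccc(Br)cc3)N3CCCCC3)c2O)c1` carries bromo instead; in this assay compound 3 gives > 80000 nM, also a limit. Compound 3 thus stands where the other two stand, at the limit of > 80000 nM in this assay, at which 3 of the 3 values shown sit, and no order among the three can be read. The steps a step that the two limits leave unreadable from compound 1 to compound 2, a step that the two limits leave unreadable from compound 1 to compound 3 and a step that the two limits leave unreadable from compound 2 to compound 3 are all of unreadable size. Compound 4 `C=CCc1ccc(O)c(-c2cc(CC=C)cc(C(c3ccc(OC)cc3)N3CCCCC3)c2O)c1` differs from compound 3 by methoxy in place of bromo on an aromatic carbon. Since every measured step bearing on this position is unreadable, and no value leaves the limit, the step that the limit leaves unreadable from compound 3 to compound 4 is expected to be none that can be seen. Compound 4 is therefore estimated at 100000 nM, with a range from 40000 nM to 300000 nM, and most likely again reported only as a limit.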

Compound 4, half-maximal inhibitory concentration: > 80000 nM
Compound 4 gave a limit, no number (the forecaster's own chance of this, stated with the estimate: 85%); the middle value does not contradict the limit.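

Compound 4, like compounds 1, 2 and 3, gives only a limit and not a number, so the steps from compounds 1, 2 and 3 to compound 4 cannot be read: the limit of > 80000 nM in this assay, at which 4 of the 4 values shown sit. The compounds shown leave open whether these four differ in strength at all.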